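Series notes: core methyl to ethyl on compound 1

The compounds below may be only part of what the source reports. "The series", "measured", "known", "first", "only" and "open" are said of these compounds alone.

Measured so far:
compound 1 `Cc1nc2c(N)ncnc2n1[C@@H]1O[C@H](CN(C)CCC(N)=O)[C@@H](O)[C@H]1O` — 400 nM
compound 2 `Cc1nc2c(N)ncnc2n1[C@@H]1O[C@H](C[S+](C)C)[C@@H](O)[C@H]1O` — 3000 nM
compound 3 `CNc1nc2c(N)ncnc2n1[C@@H]1O[C@H](CN(C)CCCCON)[C@@H](O)[C@H]1O` — 49 nM

In an assay on isolated protein for inhibition of S-adenosylmethionine decarboxylase proenzyme (Homo sapiens) (a higher number here means a weaker inhibitor, a lower number a stronger inhibitor), compound 1 gives 400 nM and stands second highest of the three numbers. Its nearest neighbour is compound 2, reached by the step of a 7.5-fold higher number from compound 1 to compound 2 (0.88 log units; beyond the scatter), in which the chain on the saturated chain carbon bound to the saturated ring carbon is exchanged. For the measured compounds named here, compound 3 gives 49 nM, a lower number than compound 1, but compound 3 differs from compound 1 in more than one place, so no single step can be drawn between them.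

Compound 4 `CCc1nc2c(N)ncnc2n1[C@@H]1O[C@H](CN(C)CCC(N)=O)[C@@H](O)[C@H]1O` differs from compound 1 by methyl in place of hydrogen on a saturated chain carbon bound to an aromatic carbon. Going by the values given here, no measured step touches this part of the shared core: the one single-point step, a 7.5-fold higher number from compound 1 to compound 2 (0.88 log units; beyond the scatter), concerns the chain at the other end of the molecule and does not bear on the change here. With nothing in the series speaking for a shift, the expected step from compound 1 to compound 4 is no change at the digits printed from compound 1 to compound 4 (within the scatter), within the scatter. Compound 4 is therefore estimated at 400 nM, with a range from 150 nM to 1100 nM.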

Compound 4, half-maximal inhibitory concentration: 4000 nM
Compound 4: the middle estimate sits 10-fold (1.00 log units) below what was measured; the measured number lies above the stated range.
By their numbers in this assay, from the lowest: compound 3; then compound 1; then compounds 2 and 4 (each within the scatter of the next).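

In this assay, the core position is not indifferent to the methyl to ethyl change: a 10-fold higher number from compound 1 to compound 4 (1.00 log units; beyond the scatter), from methyl in place of hydrogen on a saturated chain carbon bound to an aromatic carbon. This single added carbon moves the number about as far as the whole chain exchange at the other end of the molecule, a 7.5-fold higher number from compound 1 to compound 2 (0.88 log units; beyond the scatter), although this rests on one pair at the core position. Nothing at hand accounts for the size of the step.

As far as these compounds go, whether the rise stays the same or grows with a longer chain such as propyl, and how a cyclopropyl or hydroxymethyl group would read here, stays open. Also open, from the compounds shown here alone, is whether the methyl to ethyl change gives a step of this size with the chain of compound 2.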